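A few compounds are considered here, and "the series" means these few. Any claim that something is new, unique, unknown or untested is made for them only; others in the source may bear on it.

Compound 1, `COc1ccc(/C=N\NC(=S)NC(C)(C)CCC[C@](C)(O)[C@@H]2CC=C(C)CC2)cc1`, in a functional assay on MCF7 cells (Homo sapiens) for cytotoxicity, read by sulforhodamine B assay (on this read-out lower numbers stand for higher toxicity in this test and higher numbers for lower toxicity in this test), gives > 100000 nM, which is a limit of the assay and not a number.
Compound 2, `CC1=CC[C@@H]([C@@](C)(O)CCCC(C)(C)NC(=S)N/N=C\c2ccc([N+](=O)[O-])cc2)CC1`, in this assay gives > 100000 nM, again a limit of the assay.

Compound 1 therefore has no fixed place on the scale: its value is one of the two that sit at the limit of > 100000 nM in this assay, at which 2 of the 2 values shown sit, the edge of what this assay reports. For the measured compounds named here, the only measured step, a step that the two limits leave unreadable from compound 1 to compound 2, cannot be sized, as both of its ends are limits.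

Compound 3, `CC1=CC[C@@H]([C@@](C)(O)CCCC(C)(C)NC(=S)N/N=C(/C)c2ccccc2)CC1`, differs from compound 1 by a group of 9 heavy atoms (8 carbon, 1 nitrogen; one six-membered aromatic ring of carbon only) in place of a group of 10 heavy atoms (8 carbon, 1 nitrogen, 1 oxygen; one six-membered aromatic ring of carbon only), on an amide-type nitrogen. Going by the values given here, no measured step touches this part of the molecule, and the one step that exists gives no readable size. With both measured compounds resting at the limit, no sign of a shift in either direction is available. The step from compound 1 to compound 3 is expected to be a number no higher from compound 1 to compound 3 (the limit leaves the size open), that is, nothing beyond the scatter. Compound 3 is estimated at 100000 nM in this assay, with a range from 30000 nM to 300000 nM, and most likely it too will be reported only as a limit.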

Compound 3, concentration lethal to 50% of the cells: > 100000 nM
Compound 3 ended at the assay's limit; the forecaster's own chance of this, stated with the estimate: 75%; the middle value lies on the limit itself.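

Compound 3 also ends at a limit of the assay, so neither the step between compound 1 and compound 2 nor the step between compound 1 and compound 3 can be read. What stays open is whether compound 1, compound 2 and compound 3 differ at all in this assay, since all share one edge: the limit of > 100000 nM in this assay, at which 3 of the 3 values shown sit.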